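This account rests on a few compounds, and the source may have more. Where it says the series, first, only, none or still open, it means among the compounds named here.

Compound 1, `ClCc1ccccc1Cn1cnc2c(Cl)ncnc21`: in a functional assay on 786-0 cells (Homo sapiens) for cytotoxicity, read by sulforhodamine B assay, with a stated time of 48 h (a lower number here means that less compound is tolerated, a higher number that more compound is tolerated), compound 1 gives 83200 nM
Compound 2, `ClCc1cccc(Cn2cnc3c(Cl)ncnc32)c1`: compound 2 gives 50100 nM

Compound 2 stands at one end of the two numbers, with compound 1 within the scatter of it, so the two cannot be told apart. Compound 3, `ClCc1cccc(Cn2cnc3c(Cl)nc(Cl)nc32)c1`, differs from compound 2 by chloro in place of hydrogen on an aromatic carbon. No measured pair among these compounds shows this change, so the expectation is for no step beyond the scatter in this assay, with perhaps a slight drift to a lower number. Compound 3 is expected to give 40000 nM, within 15000 nM to 100000 nM. This expectation amounts to a 1.3-fold lower number from compound 2 to compound 3 (0.10 log units; within the scatter).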

Compound 3, concentration lethal to 50% of the cells: 57500 nM
Compound 3: middle estimate off by 1.4-fold (0.16 log units), on the low side, and the stated range covers the measured number.
By their numbers in this assay, from the lowest: compounds 2, 3 and 1 (each within the scatter of the next).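

In this assay, chloro in place of hydrogen on the aromatic carbon between two ring nitrogen atoms gives a 1.1-fold higher number from compound 2 to compound 3 (0.06 log units; within the scatter). This is the first step shown at this position, and it shows that the position carries a chloro group with no step beyond the scatter. Nothing measured here bears on why the number holds at this position. On these data alone, whether an amine or a methoxy group on the same carbon would also stay within the scatter remains open. So does whether this holds for the chloromethyl group of compound 1, where it sits elsewhere on the benzene ring.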